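A Ring Amine in Place of Dimethylamino

The source may report more compounds than this note shows. Statements on the series, on what has been measured and on what is new or still open speak of the compounds shown alone.

Two compounds set the frame. Compound 1 `CC(C)(O)c1nc(-c2ccc(CNC(=O)c3cnc(-c4ccccn4)nc3)cc2)no1` in an assay for binding affinity to Hematopoietic prostaglandin D synthase (Homo sapiens), read by reporter gene assay and NMR (on this read-out higher numbers stand for weaker binding and lower numbers for tighter binding), gives 23 nM. Compound 2 `CN(C)CCC(=O)Nc1cncc(-c2cccc3[nH]ccc23)c1` in this assay gives 340 nM, the higher of the two numbers, and the gap between it and compound 1 lies beyond the usual scatter, so compound 2 is the weaker binder of the pair.

Compound 3 `O=C(CCN1CCCCC1)Nc1cncc(-c2cccc3[nH]ccc23)c1` carries a single change from compound 2: piperidin-1-yl in place of dimethylamino on a saturated chain carbon, two bonds along the chain from a carbonyl carbon. Among the compounds with values here, no measured pair shows what this change does here, and compound 1 is too different in its core to speak to it. The change keeps the amine basic nitrogen on its chain and swaps only the two methyl groups for a ring closing over them.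

The step from compound 2 to compound 3 is therefore expected to be small, a 1.1-fold lower number from compound 2 to compound 3 (0.05 log units; within the scatter), with no direction favoured beyond the scatter. Compound 3 is expected to give about 300 nM, within a range from 120 nM to 800 nM.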

Compound 3, dissociation constant: 1000 nM
Compound 3: middle estimate off by 3.3-fold (0.52 log units), on the low side, and the stated range ends below it.
By their numbers in this assay, from the lowest: compound 1; then compound 2; then compound 3.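

Piperidin-1-yl in place of dimethylamino on a saturated chain carbon, two bonds along the chain from a carbonyl carbon, is the first change here with a measured outcome: in this assay it gives a 2.9-fold higher number from compound 2 to compound 3 (0.47 log units; beyond the scatter) and so weakens binding modestly. This position therefore does not tolerate the swap unchanged, even though the enlarged group, with 6 heavy atoms against 3, keeps its single nitrogen. No measurement shown explains the loss.

The two compounds cannot separate the effect of the ring from that of the added atoms, and diethylamino, pyrrolidin-1-yl or morpholin-4-yl at this place would bear on that question. Going by these compounds, how a shorter or longer chain would carry either amine also remains open.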